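Removing the propyl branch from compound 1

The compounds below may be only part of what the source reports. "The series", "measured", "known", "first", "only" and "open" are said of these compounds alone.

The series shares a biphenyl acid joined through a two-carbon linker to a substituted imidazole. Compound 1 `CCCCc1cnc(C(CCC)Cc2ccc(-c3ccccc3C(=O)O)cc2)[nH]1` carries a propyl group on that linker; in an in vitro functional assay on cells for agonist activity at Bombesin receptor subtype-3 (Homo sapiens), read by luminescence and calcium flux (a lower number here means that less compound is needed, a higher number that more compound is needed for the effect), compound 1 gives 1180 nM, the highest of the three numbers measured. Compound 2 `O=C(O)c1ccccc1-c1ccc(CCc2ncc(CC3CCCC3)[nH]2)cc1` gives 133 nM and compound 3 `CC(C)(C)Cc1cnc(CCc2ccc(-c3ccccc3C(=O)O)cc2)[nH]1` gives 106 nM; both have an unbranched linker and differ only in the group on the imidazole, and that single step, a 1.3-fold lower number from compound 2 to compound 3 (0.10 log units; within the scatter), stays within the scatter. Compound 4 `CCCCc1cnc(CCc2ccc(-c3ccccc3C(=O)O)cc2)[nH]1` is compound 1 with hydrogen in place of propyl on a saturated chain carbon bound to an aromatic carbon and a saturated chain carbon. Among the measured compounds shown here, no measured step covers this exact change, so the expectation rests on the fact that the two unbranched compounds, compound 2 and compound 3, both sit well below compound 1, while the imidazole substituent itself mattered little in the one step seen. He therefore expects the number to fall, by about a 5.9-fold lower number from compound 1 to compound 4 (0.77 log units; beyond the scatter). For compound 4 the estimate is 200 nM, with a range from 70 nM to 600 nM.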

Compound 4, half-maximal effective concentration: 2710 nM
The estimate for compound 4 lay 14-fold (1.13 log units) below the measured number; measured number above the stated range.
By their numbers in this assay, from the lowest: compounds 3 and 2 (each within the scatter of the next); then compound 1; then compound 4.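

Hydrogen in place of propyl on this saturated chain carbon does not lower the number in this assay but raises it, a 2.3-fold higher number from compound 1 to compound 4 (0.36 log units; beyond the scatter), so the propyl branch alone does not account for the high number of compound 1. Among the compounds shown here, the larger steps lie elsewhere: propyl in place of tert-butyl gives a 26-fold higher number from compound 3 to compound 4 (1.41 log units; beyond the scatter), and propyl in place of cyclopentyl gives a 20-fold higher number from compound 2 to compound 4 (1.31 log units; beyond the scatter), so the group on the saturated chain carbon bound to an aromatic carbon can matter far more than the one earlier step suggested. Nothing at hand explains either finding.

From the compounds shown here alone, it remains open whether a methyl, a hydroxyl or an amine on the branching carbon would fall closer to hydrogen or to propyl. Going by these compounds, it is also open whether the branch would have the same effect alongside tert-butyl or cyclopentyl.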